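A Methyl Added Where Activity Has Already Run Out

The source may hold more compounds than are shown below. What is called first, only, known or untested is meant among the compounds shown, and "the series" means these compounds.

Three measured compounds share a common core joined through different linkers. In a functional assay on HeLa cells (Homo sapiens) for antiproliferative activity, read by MTT assay, with a stated time of 48 h (on this read-out lower numbers stand for stronger inhibition and higher numbers for weaker inhibition), compound 1 `O=c1ccc2ccc(Oc3no[n+]([O-])c3S(=O)(=O)c3ccccc3)cc2o1` gives 4550 nM. Compound 2 `Cc1cc(=O)oc2cc(SCCOc3no[n+]([O-])c3S(=O)(=O)c3ccccc3)ccc12` gives 24 nM in this assay, a lower value than compound 1, but the two differ in more than one place. Compound 3 `O=C(COc1ccc2ccc(=O)oc2c1)OCCOc1no[n+]([O-])c1S(=O)(=O)c1ccccc1` gives > 20000 nM, which is a limit of the assay rather than a number. For compound 3 this is the limit of > 20000 nM in this assay, at which 1 of the 3 values shown sits, so it stands at the weak end of the numbers shown. Compound 4 `Cc1cc(=O)oc2cc(OCC(=O)OCCOc3no[n+]([O-])c3S(=O)(=O)c3ccccc3)ccc12` differs from compound 3 by methyl in place of hydrogen on an aromatic carbon. Within the data shown here, no measured step of this kind is available, so no change beyond the usual scatter is expected. Compound 4 is therefore estimated at 25000 nM, with a range from 5000 nM to 100000 nM. That amounts to an expected step that the limit leaves unreadable from compound 3 to compound 4.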

Compound 4, half-maximal inhibitory concentration: 4310 nM
Compound 4: the middle estimate sits 5.8-fold (0.76 log units) above what was measured; the measured number lies below the stated range.
By their numbers in this assay, from the lowest: compound 2; then compounds 4 and 1 (each within the scatter of the next). At a limit, above all of these: compound 3.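

In this assay, methyl in place of hydrogen on an aromatic carbon gives an at least 4.6-fold lower number from compound 3 to compound 4 (0.66 log units; beyond the scatter) and so provides the first single-place comparison among these compounds. It shows that this one carbon added to the shared core can shift the read-out, even from a compound at the weak end. The step is only a minimum, for compound 3 is a limit and not a number: the limit of > 20000 nM in this assay, at which 1 of the 4 values shown sits.

On these data alone, whether an ethyl or an amine at this position would shift the read-out further stays open. So does the size of the methyl step on the linkers of compound 1 and compound 2.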